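A longer chain on compound 1

The compounds below may be only part of what the source reports. "The series", "measured", "known", "first", "only" and "open" are said of these compounds alone.

Measured in a functional assay on K562 cells (Homo sapiens) for antiproliferative activity, read by MTT assay, with a stated time of 48 h; a lower number here means a stronger inhibitor, a higher number a weaker inhibitor:
Compound 1 `O=C(CCCCCC(=O)Nc1nnc(-c2cccs2)s1)NO`: > 60000 nM, a limit
Compound 2 `O=C(CCCCCC(=O)Nc1nnc(-c2cccnc2)s1)NO`: > 60000 nM, a limit

Compound 1 has no number in this assay, only the limit > 60000 nM. Compound 2 likewise gives only a limit, so the whole record so far is the limit of > 60000 nM in this assay, at which 2 of the 2 values shown sit.

The next compound, compound 3 `O=C(CCCCCCC(=O)Nc1nnc(-c2cccs2)s1)NO`, differs from compound 1 in its chain. The change is (hydroxycarbamoyl)methyl in place of hydroxycarbamoyl on a saturated chain carbon, five bonds along the chain from a carbonyl carbon.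

Within the data shown here, the one measured step is a step that the two limits leave unreadable from compound 1 to compound 2. It concerns the aromatic group rather than the chain, and it gives no size to carry over. The data therefore fix no size for the new step. A readable result for compound 3 could only lie toward a lower number, a stronger inhibitor, and another limit remains quite possible. A modest gain is assumed, and the expected change is an at least 2.0-fold lower number from compound 1 to compound 3 (0.30 log units; that floor lies within the scatter). For compound 3 the estimated value is 30000 nM, with an expected range from 5000 nM to 80000 nM.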

Compound 3, half-maximal inhibitory concentration: 1560 nM
Compound 3: middle estimate off by 19-fold (1.28 log units), on the high side; the measured number lies below the stated range.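

The longer chain brings an at least 38-fold lower number from compound 1 to compound 3 (1.58 log units; beyond the scatter) in this assay and so shows that this saturated chain position, five bonds along the chain from a carbonyl carbon, responds strongly when (hydroxycarbamoyl)methyl replaces hydroxycarbamoyl. The earlier pair could show nothing of the kind, as its step between two limits cannot be read, whereas compound 3 gives the only actual number among the compounds shown and places this series within readable range. The step is still a floor and not a full size, and the true gap may be wider, because the starting point is a limit and not a number: the limit of > 60000 nM in this assay, at which 2 of the 3 values shown sit.

The compounds shown leave open whether a still longer chain, such as 2-(hydroxycarbamoyl)ethyl at this position, would go further or lose ground, and whether the pyridin-3-yl group of compound 2 would also give a readable number on the longer chain. They also leave open whether the hydroxycarbamoyl end itself is needed for this gain, which a carboxylic acid or an amine in its place on the same chain would test.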